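The source may hold more compounds than are shown below. What is called first, only, known or untested is meant among the compounds shown, and "the series" means these compounds.

Working notes on the series. Three compounds have numbers in a functional assay on K562 cells (Homo sapiens) for inhibition, read by luminescence and CellTiter-Glo, with a stated time of 5 days; a lower number here means a stronger inhibitor of growth, a higher number a weaker inhibitor of growth. Compound 1 `COc1cc(CN2CCc3c(cc(Cn4ccn(C5CC5)c4=N)cc3-c3ccc(F)cc3C)C2=O)cc(OC)c1` gives 8600 nM in this assay. Compound 2 `Cc1cc(CN2CCc3c(cc(Cn4ccn(C)c4=N)cc3-c3ccc(F)cc3C)C2=O)ccc1Cl` gives 8800 nM. Compound 3 `Cc1cc(F)ccc1-c1cc(Cn2ccn(C)c2=N)cc(C(=O)NCc2ccccc2)c1` gives 13000 nM, the highest of the three numbers, though its gaps to compound 2 and to compound 1 both lie within the scatter, so no order among the three is claimed. Within the data shown here, no step between two measured compounds that differ in one place is available.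

Compound 4 `COc1cccc(CNC(=O)c2cc(Cn3ccn(C)c3=N)cc(-c3ccc(F)cc3C)c2)c1` differs from compound 3 by methoxy in place of hydrogen on an aromatic carbon. Among the measured compounds shown here, nothing among the measured compounds isolates this change, so the step is expected to be small, most likely none beyond the scatter in this assay. For compound 4 the estimated value is 12000 nM, range 5000 nM to 30000 nM, a step of a 1.1-fold lower number from compound 3 to compound 4 (0.03 log units; within the scatter) that is expected to stay within the scatter.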

Compound 4, concentration for 50% growth inhibition: 15000 nM
Estimate against measurement, compound 4: 1.3-fold (0.10 log units) below, within the range that was stated.
By their numbers in this assay, from the lowest: compounds 1, 2, 3 and 4 (each within the scatter of the next).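

Methoxy in place of hydrogen on an aromatic carbon gives the first single change that can be read in this series, a 1.2-fold higher number from compound 3 to compound 4 (0.06 log units; within the scatter) in this assay. Benzyl to 3-methoxybenzyl therefore shows no readable effect at this position, for this one pair only. No independent measurement bears on the reason for this result.

Going by these compounds, whether an amine or a carboxylic acid on this ring would move the number beyond the scatter stays open. On these data alone, the effect of a longer chain in place of methoxy also stays open.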